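The compounds below may be only part of what the source reports. "The series", "measured", "known", "first", "only" and "open" are said of these compounds alone.

Compound 1 `CC1=C(C(=O)Nc2ccc(F)cc2)C(c2ccc(Br)cc2)n2c(s/c(=C/c3ccc(Cl)cc3Cl)c2=O)=N1` carries a 2,4-dichlorophenyl group on the shared core; in a functional assay on the whole organism (strain albino) for inhibition, with Rattus norvegicus as the target, read by paw edema, with stated times of 1 h and 3 h, at a dose of 25 mg/kg by the oral route (a higher number here means more inhibition at the dose given (going by the name of the read-out), a lower number less inhibition), compound 1 gives 14%. Compound 2 `CC1=C(C(=O)Nc2ccc(F)cc2)C(c2ccc(Br)cc2)n2c(s/c(=C/c3ccc(Cl)cc3)c2=O)=N1` differs from it in one place, (hydrogen in place of chloro on an aromatic carbon), and in this assay compound 2 gives 25%. The step of a number 11 percentage points higher from compound 1 to compound 2 (beyond the scatter) is the only measured step of this kind in the series. Compound 3 `CC1=C(C(=O)Nc2ccc(F)cc2)C(c2ccc([N+](=O)[O-])cc2)n2c(s/c(=C/c3ccccc3Cl)c2=O)=N1` has a different core; the difference between the two cores is not broken down here. In this assay compound 3 gives 19%, a number within the scatter of both compound 1 and compound 2, so no order among these three is claimed. Compound 4 `CC1=C(C(=O)Nc2ccc(F)cc2)C(c2ccc([N+](=O)[O-])cc2)n2c(s/c(=C/c3ccccc3)c2=O)=N1` has not been measured. It differs from compound 3 in one place, (hydrogen in place of chloro on an aromatic carbon). Going by the values given here, this is the same kind of change as the one from compound 1 to compound 2, not the same: there the place was also meta to a chloro group, here it is not. Among the compounds with values here, the step expected here is a number 11 percentage points higher from compound 3 to compound 4 (beyond the scatter), resting on compound 1 because a number 11 percentage points higher from compound 1 to compound 2 (beyond the scatter) is the single comparable step, so the size is uncertain. For compound 4 the estimate is 30%, between 15% and 42%.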

Compound 4, a percentage reported as inhibition, in the whole organism at one dose (the size of the read-out at that dose, not a potency): 7%
Compound 4: middle estimate off by 23 percentage points, on the high side; the whole stated range lies above it.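

In this assay, removing the chloro group gives a number 12 percentage points lower from compound 3 to compound 4 (beyond the scatter), so the step seen on the core of compound 1 cannot be carried over to the core of compound 3, in size or in direction: the same change on two cores in this assay, a number 11 percentage points higher (beyond the scatter) from compound 1 to compound 2 and a number 12 percentage points lower (beyond the scatter) from compound 3 to compound 4, 23 percentage points apart, beyond the scatter of two such steps

For this series, then, the change has to be read separately on each core, and a step measured on one core gives no safe estimate on another. What is not shown is which difference between the two pairs matters, since the cores differ and a chloro group stays on the ring in compound 2 while none stays in compound 4, and each core offers only one pair.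

Open is whether other pairs on these two cores would follow either step. Also open, as far as these compounds go, is how a methoxy group, an amine or a carboxylic acid in place of the chloro on the 2-chlorophenyl ring of compound 3 would read out in this assay.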